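Swapping a Prenyl Ether for a Trifluoromethylbenzyl Ether

This account rests on a few compounds, and the source may have more. Where it says the series, first, only, none or still open, it means among the compounds named here.

Compound 1 `COc1cc(OC)c(-c2coc3cc(OCC=C(C)C)ccc3c2=O)cc1OC` gives 3500 nM in a functional assay on U-251 cells (Homo sapiens) for antiproliferative activity, read by MTT assay, with a stated time of 24 h; a lower number here means a stronger inhibitor, a higher number a weaker inhibitor.
Compound 2 `COc1cccc(C(=O)Oc2ccc3c(=O)c(-c4cc(OC)c(OC)cc4OC)coc3c2)c1` gives only a limit, > 10000 nM.
Compound 3 `COc1cc(OC)c(-c2coc3cc(OCc4ccccc4Br)ccc3c2=O)cc1OC` likewise gives only a limit, > 10000 nM.

Within the data shown here, compound 1 holds the only firm number; the other two sit at the limit of > 10000 nM in this assay, at which 2 of the 3 values shown sit. The steps from it are an at least 2.8-fold higher number from compound 1 to compound 2 (0.45 log units; beyond the scatter) and an at least 2.8-fold higher number from compound 1 to compound 3 (0.45 log units; beyond the scatter), both towards weaker inhibition. Compound 4 `COc1cc(OC)c(-c2coc3cc(OCc4cccc(C(F)(F)F)c4)ccc3c2=O)cc1OC` differs from compound 1 by 3-(trifluoromethyl)phenyl in place of 2-methylprop-1-en-1-yl on a saturated chain carbon bound to an oxygen on an aromatic ring. Among the measured compounds shown here, the nearest measured step is the one to compound 3, which also places a benzyl group there and gave an at least 2.8-fold higher number from compound 1 to compound 3 (0.45 log units; beyond the scatter), so compound 4 is expected to weaken by about a 2.9-fold higher number from compound 1 to compound 4 (0.46 log units; beyond the scatter). For compound 4 the estimated value is 10000 nM, between 4000 nM and 30000 nM.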

Compound 4, half-maximal inhibitory concentration: > 10000 nM
Compound 4 was reported as a limit (the forecaster's own chance of this, stated with the estimate: 55%); the middle value lies on the limit itself.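

In this assay, a second benzyl group on this oxygen, 3-(trifluoromethyl)benzyl in place of 3-methylbut-2-en-1-yl, also weakens the result, with an at least 2.8-fold higher number from compound 1 to compound 4 (0.45 log units; beyond the scatter), so the loss seen with compound 3 is not confined to 2-bromobenzyl. Compound 4 gives only a limit, > 10000 nM, not a number. The steps to compound 4 from compound 2 and compound 3 join two limits and cannot be read, and the set now crowds at one ceiling: the limit of > 10000 nM in this assay, at which 3 of the 4 values shown sit.

Left open is whether plain benzyl, a saturated 3-methylbutyl chain or a chain ending in an amine on this oxygen would match compound 1 at 3500 nM.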